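The source may hold more compounds than are shown below. What is called first, only, known or untested is meant among the compounds shown, and "the series" means these compounds.

Compound 2 `CCCSc1nc(N/N=C/c2ccc(Cl)cc2)c2nnn(Cc3ccccc3)c2n1` sits at the edge of the measurable range: in a functional assay on ECa-109 cells (Homo sapiens) for antiproliferative activity, read by MTT assay, with a stated time of 72 h (a higher number here means a weaker inhibitor, a lower number a stronger inhibitor), compound 2 gives > 64000 nM, which is a limit of the assay and not a number, so its standing is known only as a floor, as described by the limit of > 64000 nM in this assay, at which 1 of the 3 values shown sits. The measured neighbours give some footing. Compound 1 `CCCSc1nc(N/N=C(\C)c2ccc(O)cc2)c2nnn(Cc3ccccc3)c2n1` gives 32500 nM in this assay, and compound 3 `CCCSc1nc(N/N=C(\C)c2ccccc2O)c2nnn(Cc3ccc(F)cc3)c2n1` gives 21900 nM. For the measured compounds named here, the one step that touches the same part of the molecule, an at least 1.9-fold higher number from compound 1 to compound 2 (0.29 log units; that floor lies within the scatter), shows a shift toward weaker inhibition, though its floor lies within the scatter.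

Compound 4 `CCCSc1nc(N/N=C/c2c[nH]c3ccccc23)c2nnn(Cc3ccccc3)c2n1` changes the same position again: 1H-indol-3-yl in place of 4-chlorophenyl on a carbon with a double bond to nitrogen. Going by the values given here, no measured step covers this particular exchange, so the expectation rests only on the fact that compound 2 already sits at the limit and that the one related step moved weaker. Compound 4 is therefore expected to stay weak, and its estimated value in this assay is 50000 nM, within 15000 nM to 150000 nM, an expected step of an at least 1.2-fold lower number from compound 2 to compound 4 (0.10 log units; that floor lies within the scatter) from the floor of compound 2.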

Compound 4, half-maximal inhibitory concentration: 8690 nM
Compound 4: middle estimate off by 5.8-fold (0.76 log units), on the high side; the measured number lies below the stated range.
By their numbers in this assay, from the lowest: compound 4; then compounds 3 and 1 (each within the scatter of the next). At a limit, above all of these: compound 2.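

Exchanging 4-chlorophenyl for 1H-indol-3-yl on a carbon with a double bond to nitrogen gives, in this assay, an at least 7.3-fold lower number from compound 2 to compound 4 (0.86 log units; beyond the scatter), so a change at this place can move the number beyond the scatter, which the earlier step's floor did not show. The true size of this step remains unknown, because compound 2 stands at a limit of the assay and not at a number: the limit of > 64000 nM in this assay, at which 1 of the 4 values shown sits.

The entering group brings both a five-membered aromatic ring with 1 hetero atom and a hydrogen-bond donor, and this single exchange cannot show which of them matters, if either does. It also leaves open how this place would respond to an amine or a carboxylic acid on the six-membered aromatic ring.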